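Notes on the aryl change from compound 3 to compound 4

The source may hold more compounds than are shown below. What is called first, only, known or untested is meant among the compounds shown, and "the series" means these compounds.

Compound 1 `COc1cc2c(Oc3ccc(NC(=O)c4cn(-c5ccccc5)nn4)cc3F)ccnc2cc1OCCCN1CCCC1` gives 280 nM in a functional assay on NCI-H460 cells (Homo sapiens) for cytotoxicity, read by MTT assay, with a stated time of 72 h; a higher number here means a weaker inhibitor, a lower number a stronger inhibitor. Compound 2 `COc1cc2c(Oc3ccc(NC(=O)c4cn(-c5ccc(Br)cc5)nn4)cc3F)ccnc2cc1OCCCN1CCCC1` gives 200 nM in this assay. Compound 3 `COc1cc2c(Oc3ccc(NC(=O)c4cn(-c5ccccc5C)nn4)cc3F)ccnc2cc1OCCCN1CCCCC1` gives 2100 nM in this assay and stands highest of the three measured numbers, beyond the scatter from both compound 1 and compound 2. Compound 4 `COc1cc2c(Oc3ccc(NC(=O)c4cn(-c5c(Cl)cccc5Cl)nn4)cc3F)ccnc2cc1OCCCN1CCCCC1` is not yet measured; it differs from compound 3 by 2,6-dichlorophenyl in place of 2-methylphenyl on an aromatic nitrogen. Within the data shown here, the only measured step on the same phenyl is a 1.4-fold lower number from compound 1 to compound 2 (0.15 log units; within the scatter), a change within the scatter; no measured step covers the 2-methyl or the 2,6-dichloro pattern, so the expectation leans on compound 3 itself. The step is therefore expected to be a 1.2-fold higher number from compound 3 to compound 4 (0.08 log units; within the scatter), with no direction called beyond the scatter. Compound 4 is estimated at 2500 nM in this assay, within a range of 800 nM to 8000 nM.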

Compound 4, half-maximal inhibitory concentration: 280 nM
Compound 4: the middle estimate sits 8.9-fold (0.95 log units) above what was measured; measured number outside the range, below it.
By their numbers in this assay, from the lowest: compounds 2, 1 and 4 (each within the scatter of the next); then compound 3.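

On the aromatic nitrogen of the five-membered aromatic ring with 3 nitrogen, 2,6-dichlorophenyl in place of 2-methylphenyl gives a 7.5-fold lower number from compound 3 to compound 4 (0.88 log units; beyond the scatter) in this assay. The aryl group at this position can therefore move the number beyond the scatter, which the bromo step on the phenyl, within the scatter, did not show. No available measurement accounts for this step. The compounds shown leave open whether 2-chlorophenyl or 2,6-dimethylphenyl would read like compound 3 or like compound 4, and so whether one chlorine is enough.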